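Ester and amide analogues of a shared core: cytotoxicity notes

A few compounds are considered here, and "the series" means these few. Any claim that something is new, unique, unknown or untested is made for them only; others in the source may bear on it.

compound 1 `O=C(NCc1ccccc1)c1cn(-c2ccccc2)nc1-c1ccncc1` — in a functional assay on HL-60 cells (Homo sapiens) for cytotoxicity, read by MTT assay, with a stated time of 48 h (on this read-out higher numbers stand for weaker inhibition and lower numbers for stronger inhibition), compound 1 gives > 100000 nM, a limit of the assay
compound 2 `CCc1ccc(OC(=O)c2cn(-c3ccccc3)nc2-c2ccncc2)cc1` — compound 2 gives "nd(insoluble)" (no result reported)
compound 3 `O=C(Oc1ccc(-c2ccccc2)cc1)c1cn(-c2ccccc2)nc1-c1ccncc1` — compound 3 gives "nd(insoluble)" (no result reported)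

Compound 2 has no number in this assay: its entry carries no result. Of the two other entries, compound 1 sits at a limit of the assay (the limit of > 100000 nM in this assay, at which 1 of the 3 values shown sits), and compound 3 likewise gives no result. Compound 4 `O=C(Oc1ccc2ccccc2c1)c1cn(-c2ccccc2)nc1-c1ccncc1` remains to be measured. The change is naphthalen-2-yl in place of 4-ethylphenyl on an oxygen next to a carbonyl group. For the measured compounds named here, no step between measured compounds exists, so neither a direction nor a size can be read from it; for compound 4 no shift beyond the scatter is expected, and a further entry without a number is thought likely. The estimate for compound 4 in this assay is 100000 nM, with a range from 30000 nM to 300000 nM.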

Compound 4, half-maximal inhibitory concentration: > 100000 nM
Compound 4: a limit, no number; the forecaster's own chance of this, stated with the estimate: 75%; the middle value lies on the limit itself.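

Compound 4 gives > 100000 nM, a limit and not a number, and compound 2 carries no result, so no step can be read between them. The compounds shown leave open whether any analogue of the shared core reaches a numerical value in this assay.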